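The compounds below may be only part of what the source reports. "The series", "measured", "known", "first", "only" and "open" are said of these compounds alone.

Working notes on the series.

Compound 1 `COC(=O)[C@@]1(C)CCC=C2[C@@H]1CC[C@@H](C)[C@]2(C)Cc1c[nH]c2ccccc12` is the reference point. Within the data shown here, in a functional assay on T47D cells (Homo sapiens) for inhibition, read by sulforhodamine B assay, with a stated time of 48 h (on this read-out higher numbers stand for weaker inhibition of growth and lower numbers for stronger inhibition of growth), compound 1 gives 4200 nM, the highest of the two numbers so far. Compound 2 `COC(=O)[C@@]1(C)CCC=C2[C@@H]1CC[C@@H](C)[C@]2(C)Cc1c[nH]c2ccc(OC)cc12` carries a methoxy in place of hydrogen on an aromatic carbon; in this assay compound 2 gives 3700 nM. Among the measured compounds shown here, the one measured step, a 1.1-fold lower number from compound 1 to compound 2 (0.06 log units; within the scatter), lies within the scatter, so the series so far shows no substituent effect that can be trusted.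

Compound 3 `COC(=O)[C@@]1(C)CCC=C2[C@@H]1CC[C@@H](C)[C@]2(C)Cc1c(C)[nH]c2ccccc12` is the next candidate. Its change from compound 1 is methyl in place of hydrogen on an aromatic carbon, placed on an aromatic carbon of the five-membered aromatic ring with one nitrogen, next to the ring nitrogen and next to the ring atom that bears the large group. For the measured compounds named here, no measured step touches that ring or a methyl group; the only comparison available, from compound 1 to compound 2, was flat. On that basis no step beyond the scatter is expected for compound 3 in this assay, a 1.1-fold lower number from compound 1 to compound 3 (0.04 log units; within the scatter), and the estimate for compound 3 is 3800 nM, within 1600 nM to 9000 nM.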

Compound 3, concentration for 50% growth inhibition: 17000 nM
Compound 3: middle estimate off by 4.5-fold (0.65 log units), on the low side; measured number above the stated range.
By their numbers in this assay, from the lowest: compounds 2 and 1 (each within the scatter of the next); then compound 3.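

In this assay, among these compounds, methyl in place of hydrogen on an aromatic carbon of the five-membered aromatic ring with 1 nitrogen gives a 4.0-fold higher number from compound 1 to compound 3 (0.61 log units; beyond the scatter) and is the first step beyond the scatter. This position, next to the ring nitrogen and next to the ring atom that bears the large group, therefore responds to substitution: one added carbon weakens inhibition of growth, whereas the methoxy change gave only a 1.1-fold lower number from compound 1 to compound 2 (0.06 log units; within the scatter) and stayed within the scatter. No measurement at hand bears on the reason for this loss.

On these data alone, it remains open whether other groups on this carbon, such as a fluorine atom, an ethyl chain or an amine, behave like methyl. As far as these compounds go, it is also open whether the methyl step holds on the methoxy-bearing core of compound 2.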